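The source may hold more compounds than are shown below. What is called first, only, known or untested is meant among the compounds shown, and "the series" means these compounds.

Working notes on the series, read in a functional assay on MCF7 cells (Homo sapiens) for inhibition, read by sulforhodamine B assay, with a stated time of 72 h; on this read-out lower numbers stand for stronger inhibition of growth and higher numbers for weaker inhibition of growth. Compound 1 `CCOC(=O)/C=C/c1ccncc1-c1ccc2[nH]ccc2c1` reaches only a limit in this assay, > 10000 nM. Within the data shown here, compound 2 `CCOC(=O)/C=C/c1ccncc1-c1ccc2c(ccn2C)c1` gives 8670 nM, the only actual number so far. The next entry is compound 3 `Cn1ccc2cc(-c3cnccc3/C=C/C(=O)O)ccc21`, and the change is hydrogen in place of ethyl on an oxygen next to a carbonyl group, so that 2-(ethoxycarbonyl)ethenyl becomes 2-carboxyethenyl. Among the measured compounds shown here, the one measured step, an at least 1.1-fold lower number from compound 1 to compound 2 (0.06 log units; that floor lies within the scatter), is methyl in place of hydrogen on an aromatic nitrogen. It is a different change at a different place, so it sets no size for this one. With compound 2 at 8670 nM, only a small move towards weaker inhibition of growth is expected, and the expected step is a 1.6-fold higher number from compound 2 to compound 3 (0.21 log units; within the scatter). For compound 3 the estimate is 14000 nM, with an expected range from 6000 nM to 40000 nM.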

Compound 3, concentration for 50% growth inhibition: > 10000 nM
Compound 3 gave a limit, no number (the forecaster's own chance of this, stated with the estimate: 65%); the middle value is on the limit's open side.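

At this place, the carboxy group that replaces ethoxycarbonyl can be read only as an at least 1.1-fold higher number from compound 2 to compound 3 (0.06 log units; that floor lies within the scatter), so the change gives no sign of stronger inhibition of growth in this assay. Among these compounds, compound 2, with its ethyl ester, remains the only compound here with an actual number, and the earlier step gave no reading for a change on this oxygen. How far the number moves with hydrogen in place of ethyl stays undetermined because the read-out stops at a limit: the limit of > 10000 nM in this assay, at which 2 of the 3 values shown sit.

From the compounds shown here alone, whether any replacement for ethoxycarbonyl gives a number well inside the range of this assay remains open, for example a primary amide or an ester with a longer chain. Going by these compounds, it is also open whether a saturated two-carbon chain in place of the ethenyl link would keep the number of compound 2.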